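This account rests on a few compounds, and the source may have more. Where it says the series, first, only, none or still open, it means among the compounds named here.

Of the compounds shown here, three built on one shared core have been measured in a functional assay on SGC-7901 cells (Homo sapiens) for inhibition, read by MTT assay, with a stated time of 24 h; a higher number here means a weaker inhibitor, a lower number a stronger inhibitor. Compound 1 `CC1(C)[C@H]2CC[C@]1(C)N(Cc1cn(-c3ccccc3Br)nn1)C(=O)C2` gives 500 nM, compound 2 `CC1(C)[C@H]2CC[C@]1(C)N(Cc1cn(-c3ccc(F)cc3)nn1)C(=O)C2` gives 500 nM, and compound 3 `CC1(C)[C@H]2CC[C@]1(C)N(Cc1cn(-c3ccc(Br)cc3)nn1)C(=O)C2` gives 450 nM. Compound 2 thus stands level with compound 1, the two together the highest of the three numbers, and close to compound 3. Compound 4 `CC1(C)[C@H]2CC[C@]1(C)N(Cc1cn(-c3cccc(Br)c3)nn1)C(=O)C2` differs from compound 2 in one place: 3-bromophenyl in place of 4-fluorophenyl on an aromatic nitrogen. For the measured compounds named here, two measured steps bear on this change. Bromo in place of fluoro gave a 1.1-fold lower number from compound 2 to compound 3 (0.05 log units; within the scatter), and 4-bromophenyl in place of 2-bromophenyl gave a 1.1-fold lower number from compound 1 to compound 3 (0.05 log units; within the scatter). Both stayed within the scatter, so no step beyond the scatter is expected in this assay here either. Compound 4 is therefore estimated at 500 nM, in a range from 300 nM to 850 nM. That estimate means an expected no change at the digits printed from compound 2 to compound 4 (within the scatter).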

Compound 4, half-maximal inhibitory concentration: 120 nM
Compound 4: middle estimate off by 4.2-fold (0.62 log units), on the high side, and the stated range ends above it.
By their numbers in this assay, from the lowest: compound 4; then compounds 3, 1 and 2 (each within the scatter of the next).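

With the phenyl ring on the aromatic nitrogen, the place of the bromine matters in this assay: 3-bromophenyl in place of 4-bromophenyl gives a 3.8-fold lower number from compound 3 to compound 4 (0.57 log units; beyond the scatter), and in place of 2-bromophenyl it gives a 4.2-fold lower number from compound 1 to compound 4 (0.62 log units; beyond the scatter). In place of 4-fluorophenyl, it gives a 4.2-fold lower number from compound 2 to compound 4 (0.62 log units; beyond the scatter). Nothing here accounts for these steps. Still open, as far as these compounds go, is whether this gain needs bromine itself, or whether a chloro, methoxy or amine group in its place on the 3-bromophenyl ring would give a similar number.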